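This account rests on a few compounds, and the source may have more. Where it says the series, first, only, none or still open, it means among the compounds named here.

Measured compounds in a functional assay on CEM-CCRF cells for antagonist activity at C-X-C chemokine receptor type 4 (Homo sapiens), read by calcium flux; a higher number here means a weaker inhibitor, a lower number a stronger inhibitor:
- compound 1 `NCc1cccc(CN(Cc2nc3ccccc3[nH]2)C2CCCc3cccnc32)c1` gives 1400 nM
- compound 2 `NCc1ccccc1CN(Cc1nc2ccccc2[nH]1)C1CCCc2cccnc21` gives 50 nM
- compound 3 `NCCCCCN(Cc1nc2ccccc2[nH]1)C1CCCc2cccnc21` gives 514 nM

Compound 3 stands second highest of these three numbers in this assay: its nearest neighbour is compound 1, with a 2.7-fold lower number from compound 1 to compound 3 (0.44 log units; beyond the scatter) separating them, and the furthest is compound 2, with a 10-fold higher number from compound 2 to compound 3 (1.01 log units; beyond the scatter) between them. All three share the same core and differ only in the group on the amine nitrogen.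

Compound 4 `NCCCC(=O)N(Cc1nc2ccccc2[nH]1)C1CCCc2cccnc21` keeps that core and changes the same position once more: (3-aminopropyl)carbonyl in place of 5-aminopentyl on an amine nitrogen. Among the measured compounds shown here, no measured step exchanges an amine for an amide here, so none bears on this change directly. What the measured steps do show is that this position is sensitive: a 28-fold lower number from compound 1 to compound 2 (1.45 log units; beyond the scatter) and a 10-fold higher number from compound 2 to compound 3 (1.01 log units; beyond the scatter) are both large, while a 2.7-fold lower number from compound 1 to compound 3 (0.44 log units; beyond the scatter) is modest. A step beyond the scatter in this assay is therefore plausible, but its direction cannot be read from these three compounds.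

Compound 4 is expected to give about 1500 nM, within a range of 300 nM to 8000 nM, which corresponds to an estimated step of a 2.9-fold higher number from compound 3 to compound 4 (0.47 log units; beyond the scatter).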

Compound 4, half-maximal inhibitory concentration: 3200 nM
For compound 4 the middle estimate is 2.1-fold (0.33 log units) below the measured one; the measured number falls inside the stated range.
By their numbers in this assay, from the lowest: compound 2; then compound 3; then compound 1; then compound 4.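

In this assay, (3-aminopropyl)carbonyl in place of 5-aminopentyl on the amine nitrogen gives a 6.2-fold higher number from compound 3 to compound 4 (0.79 log units; beyond the scatter) even though both groups hold the same number of heavy atoms, so a carbonyl on that nitrogen goes with a weaker inhibitor here. The steps from the two benzyl compounds point the same way, with a 64-fold higher number from compound 2 to compound 4 (1.81 log units; beyond the scatter) and a 2.3-fold higher number from compound 1 to compound 4 (0.36 log units; beyond the scatter), which leaves compound 4 as the weakest inhibitor of the four. No measurement shown here accounts for this loss.

The compounds shown leave open whether a carbonyl would have the same effect on a longer chain or on an aminomethyl-bearing benzyl group. On these data alone, it also remains open how a hydroxyl or a carboxylic acid in place of the terminal amine would read on either chain.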